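Lengthening the Alkyne Amine on a Methoxy Core

The compounds below may be only part of what the source reports. "The series", "measured", "known", "first", "only" and "open" are said of these compounds alone.

Three compounds have been examined in an assay on isolated protein for inhibition of Amine oxidase [flavin-containing] A (Rattus norvegicus); on this read-out higher numbers stand for weaker inhibition and lower numbers for stronger inhibition. Compound 1 `CC#CCN(C)Cc1cc2cc(O)ccc2n1C` gives 5.7 nM, compound 2 `C#CCNCc1cc2ccccc2n1C` gives 240 nM, and compound 3 `C#CCNCc1cc2cc(OC)ccc2n1C` gives 0.8 nM. Compound 3 thus has the lowest number of the three measured, with compound 1 the nearest to it and compound 2 the furthest away. For the measured compounds named here, the only measured step between two compounds that differ in a single place runs a 300-fold lower number from compound 2 to compound 3 (2.48 log units; beyond the scatter), the introduction of a methoxy group on the shared core.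

Compound 4 `CC#CCN(C)Cc1cc2cc(OC)ccc2n1C` has not yet been measured. It differs from compound 3 in one place: (but-2-yn-1-yl)(methyl)amino in place of propargylamino on a saturated chain carbon bound to an aromatic carbon. Going by the values given here, no measured step covers this exact change. Compound 1 carries the entering group, but it also carries a hydroxy where compound 3 has a methoxy, so the two structures differ in two places and the two values cannot be pulled apart into separate contributions. What can be said is that compound 1 sits well below compound 2 and somewhat above compound 3. A modest move is therefore expected. Compound 4 is expected to show a step of a 3.1-fold higher number from compound 3 to compound 4 (0.49 log units; beyond the scatter) in this assay. The value of compound 4 is estimated at 2.5 nM, with a range from 0.6 nM to 10 nM.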

Compound 4, inhibition constant: 1.4 nM
Beside the measured number, compound 4's estimate is 1.8-fold (0.25 log units) above it, and the stated range covers the measured number.
By their numbers in this assay, from the lowest: compounds 3 and 4 (each within the scatter of the next); then compound 1; then compound 2.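

In this assay, a 1.8-fold higher number from compound 3 to compound 4 (0.24 log units; within the scatter) shows that (but-2-yn-1-yl)(methyl)amino can stand in place of propargylamino on this saturated chain carbon bound to an aromatic carbon with no change beyond the scatter, even though the entering group has 6 heavy atoms against 4 and 0 hydrogen-bond donors against 1. For the compounds shown here, compound 4 also gives the first single-place comparison of methoxy with hydroxy, and in this assay a 4.1-fold lower number from compound 1 to compound 4 (0.61 log units; beyond the scatter) is a modest step that comes from adding methyl in place of hydrogen on an oxygen on an aromatic ring. Methoxy had previously been compared only with hydrogen, on the propargylamino compounds, in a 300-fold lower number from compound 2 to compound 3 (2.48 log units; beyond the scatter), so its link to a lower number now holds in a second setting, against hydroxy and with a different amine.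

The compounds shown cannot separate the methyl from the but-2-yn-1-yl part of the entering group, which a (methyl)(propargyl)amino group would help to do, and they leave open how an ethoxy group would compare with methoxy. No measurement here explains either new step.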